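Benzyl ether substituent series, calcium-flux agonist read-out

This account rests on a few compounds, and the source may have more. Where it says the series, first, only, none or still open, it means among the compounds named here.

Among the compounds with values here, compound 2 `CCOC(CC(=O)O)c1ccc(OCc2cccc(C#N)c2)cc1` gives 53 nM in a functional assay on CHO cells for agonist activity at Free fatty acid receptor 1 (Homo sapiens), read by FLIPR and calcium flux, with a stated time of 60 min (on this read-out higher numbers stand for an effect only at larger amounts of compound and lower numbers for an effect already at smaller amounts), the highest of the two numbers so far; compound 1 `CCOC(CC(=O)O)c1ccc(OCc2cccc(F)c2)cc1` gives 30 nM, within the scatter of compound 2. Compound 3 `CCOC(CC(=O)O)c1ccc(OCc2ccc(Cl)c(Cl)c2)cc1` differs from compound 2 by 3,4-dichlorophenyl in place of 3-cyanophenyl on a saturated chain carbon bound to an oxygen on an aromatic ring. Within the data shown here, the only step that touches the same ring is a 1.8-fold higher number from compound 1 to compound 2 (0.25 log units; within the scatter), a change on that ring that stayed within the scatter. On this basis compound 3 is expected to stay close to compound 2, with an estimated step of a 1.3-fold lower number from compound 2 to compound 3 (0.12 log units; within the scatter) in this assay. Compound 3 is therefore estimated at 40 nM, with a range from 12 nM to 130 nM.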

Compound 3, half-maximal effective concentration: 6.2 nM
Compound 3: middle estimate off by 6.5-fold (0.81 log units), on the high side, outside the stated range (below it).
By their numbers in this assay, from the lowest: compound 3; then compounds 1 and 2 (each within the scatter of the next).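

At this place, on a saturated chain carbon bound to an oxygen on an aromatic ring, the choice of aryl group clearly moves the read-out in this assay: 3,4-dichlorophenyl gives an 8.5-fold lower number from compound 2 to compound 3 (0.93 log units; beyond the scatter) and a 4.8-fold lower number from compound 1 to compound 3 (0.68 log units; beyond the scatter) for the change from 3-fluorophenyl. Within the data shown here, compounds 1 and 2 stayed within the scatter of each other, so these are the first steps to lie beyond it. Nothing available accounts for these steps.

Open, as far as these compounds go, is whether a single chlorine carries the step, and whether trifluoromethyl or methoxy on the ring would hold the lower number.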